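The compounds below may be only part of what the source reports. "The series", "measured", "known", "first", "only" and "open" are said of these compounds alone.

Among the measured compounds shown here, in an ADME assay on Caco-2 cells (Homo sapiens) for permeability, in the apical to basolateral direction, at pH 7.4 (a higher number here means that the compound crosses the layer faster, a lower number that the compound crosses the layer more slowly), compound 1 `Cc1ccc2[nH]c(C(=O)N[C@H]3CN(S(=O)(=O)c4ccccc4)C[C@@H]3C(=O)N[C@H]3CCCNC3)cc2c1` gives 0.04 10^-6 cm/s and compound 2 `O=C(N[C@H]1CN(S(=O)(=O)c2ccccc2)C[C@@H]1C(=O)N[C@H]1CCCNC1)c1cc(C2CC2)n[nH]1` gives 0.39 10^-6 cm/s, the higher of the two numbers so far. For the measured compounds named here, the one measured step, a 9.8-fold higher number from compound 1 to compound 2 (0.99 log units; beyond the scatter), lies beyond the scatter. It replaces 5-methyl-1H-indol-2-yl with 3-cyclopropyl-1H-pyrazol-5-yl on a carbonyl carbon.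

Compound 3 `O=C(N[C@H]1CN(S(=O)(=O)c2ccccc2)C[C@@H]1C(=O)N[C@H]1CCCNC1)c1cc(-c2ccccc2)on1` changes the group at that same place, on a carbonyl carbon whose other neighbours are an amide-type nitrogen: 5-phenyl-1,2-oxazol-3-yl in place of 3-cyclopropyl-1H-pyrazol-5-yl on a carbonyl carbon. In words, 5-phenyl-1,2-oxazol-3-yl stands in place of 3-cyclopropyl-1H-pyrazol-5-yl.

Going by the values given here, only the step of a 9.8-fold higher number from compound 1 to compound 2 (0.99 log units; beyond the scatter) bears on this change. It shows that the number can move with the group at this place, but a single step gives no rule for a group not yet measured. That step therefore sets a rough outer size, and no firm direction follows from it. The expected change is small and no larger than the scatter, with a slight lean to a lower number: a 1.3-fold lower number from compound 2 to compound 3 (0.11 log units; within the scatter). For compound 3 the estimate is 0.3 10^-6 cm/s, with an expected range of 0.07 10^-6 cm/s to 1 10^-6 cm/s.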

Compound 3, apparent permeability: 0.12 10^-6 cm/s
The estimate for compound 3 lay 2.5-fold (0.40 log units) above the measured number; the range from low to high includes it.
By their numbers in this assay, from the lowest: compound 1; then compound 3; then compound 2.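

At this place, on a carbonyl carbon whose other neighbours are an amide-type nitrogen, a second change of group again moves the number in this assay beyond the scatter, with a 3.3-fold lower number from compound 2 to compound 3 (0.51 log units; beyond the scatter) and with a 3.0-fold higher number from compound 1 to compound 3 (0.48 log units; beyond the scatter). The three groups now form an order rather than a single step: 5-phenyl-1,2-oxazol-3-yl sits in the middle, and 3-cyclopropyl-1H-pyrazol-5-yl keeps the highest number, with its steps to both other compounds beyond the scatter, even though the entering group carries no hydrogen-bond donor and the group it replaces carries one. No measurement in hand accounts for this order.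

The step from compound 2 to compound 3 changes the ring, its substituent, the heavy-atom count and the donor count together, so the share of each in the drop stays unresolved. On these data alone, a 3-phenyl-1H-pyrazol-5-yl or a 5-cyclopropyl-1,2-oxazol-3-yl group would separate ring from substituent, and it remains open how a carboxylic acid or an aliphatic amine on the same carbonyl carbon would fall relative to these three groups.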